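Butylamino for hydroxy on the amide-ring nitrogen aryl group

The source may report more compounds than this note shows. Statements on the series, on what has been measured and on what is new or still open speak of the compounds shown alone.

Compound 1, `COc1ccc([C@H]2CC(=O)N(c3cccc(O)c3)C2)cc1OC1CCCC1`: in a functional assay on HEK293 cells (Homo sapiens) for cytotoxicity (on this read-out higher numbers stand for lower toxicity in this test and lower numbers for higher toxicity in this test), compound 1 gives > 10000 nM, a limit of the assay.
Compound 2, `COc1ccc([C@H]2CC(=O)N(c3ccc(C)c(N)c3)C2)cc1OC1CCCC1`: in this assay compound 2 gives > 10000 nM, also a limit.
Compound 3, `COc1ccc([C@H]2CC(=O)N(c3ccccc3N)C2)cc1OC1CCCC1`: in this assay compound 3 gives > 10000 nM, again a limit.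

Compound 1 stands, like the two others, at the limit of > 10000 nM in this assay, at which 3 of the 3 values shown sit; no number places it above or below them. The steps a step that the two limits leave unreadable from compound 1 to compound 2 and a step that the two limits leave unreadable from compound 1 to compound 3 and a step that the two limits leave unreadable from compound 2 to compound 3 are all unreadable in size for that reason.

The unmeasured compound 4, `CCCCNc1cccc(N2C[C@@H](c3ccc(OC)c(OC4CCCC4)c3)CC2=O)c1`, differs from compound 1 by butylamino in place of hydroxy on an aromatic carbon. Going by the values given here, none of the three measured steps changes the same position in the same way, and all three end at the limit, so they give no direction for this assay; the only evidence is that three varied aryl groups on the ring nitrogen all sit at the limit of > 10000 nM in this assay, at which 3 of the 3 values shown sit.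

Compound 4 is therefore expected to show a step that the limit leaves unreadable from compound 1 to compound 4, with the value most likely again reported only as a limit. The estimate for compound 4 in this assay is 15000 nM, between 4000 nM and 60000 nM.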

Compound 4, half-maximal cytotoxic concentration: > 10000 nM
Compound 4 was reported as a limit (the forecaster's own chance of this, stated with the estimate: 70%); the middle value does not contradict the limit.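

Compound 1 and compound 4 both sit at a limit in this assay, so the size of the step between them cannot be read: the limit of > 10000 nM in this assay, at which 4 of the 4 values shown sit. The compounds shown leave open at what concentration any of them becomes cytotoxic in this assay, and whether changing the aryl group on the ring nitrogen shifts that concentration.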